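Pyrrolidine to piperidine on the propoxy chain, second core

The source may hold more compounds than are shown below. What is called first, only, known or untested is meant among the compounds shown, and "the series" means these compounds.

Measured compounds:
compound 1 `COc1cc2c(Oc3ccc(NC(=O)c4nn(-c5cccc(F)c5)c(=O)cc4C)cc3F)ccnc2cc1OCCCN1CCCC1`: 280 nM
compound 2 `COc1cc2c(Oc3ccc(NC(=O)c4nn(-c5cccc(F)c5)c(=O)cc4C)cc3F)ccnc2cc1OCCCN1CCCCC1`: 360 nM
compound 3 `COc1ccc(-n2nc(C(=O)Nc3ccc(Oc4ccnc5cc(OCCCN6CCCC6)c(OC)cc45)c(F)c3)c(C)cc2=O)cc1`: 3610 nM

In a functional assay on NCI-H460 cells (Homo sapiens) for inhibition, read by MTT assay, with a stated time of 72 h (a higher number here means a weaker inhibitor, a lower number a stronger inhibitor), compound 1 gives 280 nM and compound 2 gives 360 nM. Compound 2 differs from compound 1 by piperidin-1-yl in place of pyrrolidin-1-yl on a saturated chain carbon, three bonds along the chain from an oxygen on an aromatic ring and this gave a 1.3-fold higher number from compound 1 to compound 2 (0.11 log units; within the scatter). Compound 3 carries a different core, (4-methoxyphenyl in place of 3-fluorophenyl on an aromatic nitrogen), with a 13-fold higher number from compound 1 to compound 3 (1.11 log units; beyond the scatter) in this assay. Compound 4 `COc1ccc(-n2nc(C(=O)Nc3ccc(Oc4ccnc5cc(OCCCN6CCCCC6)c(OC)cc45)c(F)c3)c(C)cc2=O)cc1` is not yet measured; it differs from compound 3 by piperidin-1-yl in place of pyrrolidin-1-yl on a saturated chain carbon, three bonds along the chain from an oxygen on an aromatic ring, the same change as from compound 1 to compound 2 and at the same place. Because a 1.3-fold higher number from compound 1 to compound 2 (0.11 log units; within the scatter) lay within the scatter, the same change is expected to give a 1.2-fold higher number from compound 3 to compound 4 (0.09 log units; within the scatter) in this assay. Compound 4 is therefore estimated at 4400 nM in this assay, with a likely range from 2200 nM to 9000 nM. Going by the values given here, only one prior instance of this change is available, so the expectation is weakly supported.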

Compound 4, half-maximal inhibitory concentration: 3730 nM
Beside the measured number, compound 4's estimate is 1.2-fold (0.07 log units) above it; measured number inside the range.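

In this assay, piperidin-1-yl in place of pyrrolidin-1-yl carries over to the second core without a readable effect, a 1.0-fold higher number from compound 3 to compound 4 (0.01 log units; within the scatter), and the two cores agree: the same change on two cores in this assay, a 1.3-fold higher number (0.11 log units; within the scatter) from compound 1 to compound 2 and a 1.0-fold higher number (0.01 log units; within the scatter) from compound 3 to compound 4, 1.2-fold (0.09 log units) apart, within the scatter of two such steps

The change of 4-methoxyphenyl in place of 3-fluorophenyl on an aromatic nitrogen is also large with piperidin-1-yl on the chain, a 10-fold higher number from compound 2 to compound 4 (1.02 log units; beyond the scatter), and agrees with the pyrrolidin-1-yl pair: the same change on two cores in this assay, a 13-fold higher number (1.11 log units; beyond the scatter) from compound 1 to compound 3 and a 10-fold higher number (1.02 log units; beyond the scatter) from compound 2 to compound 4, 1.2-fold (0.09 log units) apart, within the scatter of two such steps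

The two changes therefore combine without interaction across these four compounds in this one assay, but this does not show why either step has the size it has, nor that the same holds for other cores or cell lines.

Still open, going by these compounds, is whether a morpholin-4-yl or 4-methylpiperazin-1-yl group at the end of the chain would also leave the number unmoved. Also open, on these data alone, is how a 4-fluorophenyl or unsubstituted phenyl group on the aromatic nitrogen would compare.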